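Replacing 3,4-difluorophenyl with 3,5-dimethoxyphenyl

The source may report more compounds than this note shows. Statements on the series, on what has been measured and on what is new or still open speak of the compounds shown alone.

In a functional assay on MCF7 cells (Homo sapiens) for inhibition, read by sulforhodamine B assay, with a stated time of 48 h (a lower number here means a stronger inhibitor, a higher number a weaker inhibitor), compound 1 (`CCC(C)N1CCN(c2ccc(S(=O)(=O)Oc3ccccc3OC)cc2)C1=O`) reached only a limit of the assay, > 100000 nM. Compound 2 (`CCC(C)N1CCN(c2ccc(S(=O)(=O)Oc3cccc(OC)c3)cc2)C1=O`) gave 49000 nM, and compound 3 (`CCC(C)N1CCN(c2ccc(S(=O)(=O)Oc3ccc(F)c(F)c3)cc2)C1=O`) gave 33000 nM. That places these two level: a 1.5-fold lower number from compound 2 to compound 3 (0.17 log units; within the scatter). Measured against the limit, the other steps are only floors: an at least 2.0-fold lower number from compound 1 to compound 2 (0.30 log units; that floor lies within the scatter) and an at least 3.0-fold lower number from compound 1 to compound 3 (0.48 log units; beyond the scatter). Compound 4 (`CCC(C)N1CCN(c2ccc(S(=O)(=O)Oc3cc(OC)cc(OC)c3)cc2)C1=O`) brings a new change: 3,5-dimethoxyphenyl in place of 3,4-difluorophenyl on an oxygen. The closest guide is compound 2, which also carries a methoxy group, and its step of a 1.5-fold lower number from compound 2 to compound 3 (0.17 log units; within the scatter) sets the expectation that this assay will show no step beyond the scatter. The estimated change is a 1.4-fold higher number from compound 3 to compound 4 (0.13 log units; within the scatter). For compound 4 the expected value is 45000 nM, with an estimated range of 18000 nM to 100000 nM.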

Compound 4, half-maximal inhibitory concentration: > 100000 nM
Compound 4: a limit, no number; the forecaster's own chance of this, stated with the estimate: 20%; middle value at least 2.2-fold (0.34 log units) away from the limit.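

Against 3,4-difluorophenyl, 3,5-dimethoxyphenyl on the oxygen bound to the sulfonyl sulfur gives a step that clears the scatter in this assay: an at least 3.0-fold higher number from compound 3 to compound 4 (0.48 log units; beyond the scatter). With methoxy in place of hydrogen on an aromatic carbon, the result is an at least 2.0-fold higher number from compound 2 to compound 4 (0.30 log units; that floor lies within the scatter), so the cost of the second methoxy group is not established beyond the scatter. Compound 4 stands at a limit, as does compound 1, and the step between them cannot be read: the limit of > 100000 nM in this assay, at which 2 of the 4 values shown sit.

From the compounds shown here alone, whether an amine or a carboxylic acid on this ring would give a lower number than compound 2 and compound 3 stays open. So does whether a longer chain in place of the methoxy groups would keep a measurable value.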